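The source may hold more compounds than are shown below. What is called first, only, known or untested is meant among the compounds shown, and "the series" means these compounds.

Compound 1 `Cc1cc(NC(=O)Nc2cccc(F)c2)c2ccccc2n1`: > 25000 nM (a limit)
Compound 2 `Cc1cc(NC(=O)Nc2ccccc2F)c2ccccc2n1`: > 25000 nM (a limit)
Compound 3 `Cc1cc(NC(=O)Nc2ccc(Cl)cc2)c2ccccc2n1`: > 25000 nM (a limit)

In an ADME assay on Raji cells (Homo sapiens) for cytotoxicity, with a stated time of 72 h (a lower number here means that less compound is needed, a higher number that more compound is needed for the effect), compound 1 gives > 25000 nM. This is a limit of the assay and not a number, so compound 1 has no exact position. The same holds across the series: the limit of > 25000 nM in this assay, at which 3 of the 3 values shown sit.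

Compound 4 `Cc1cc(NC(=O)Nc2cccc(C(C)(C)C)c2)c2ccccc2n1` keeps the core of compound 1 and changes one group: tert-butyl in place of fluoro on an aromatic carbon. In words, this is tert-butyl in place of fluoro on an aromatic carbon.

Among the measured compounds shown here, two measured steps bear on this change, as both alter the substituted phenyl group on the same nitrogen. They are a step that the two limits leave unreadable from compound 1 to compound 2 and a step that the two limits leave unreadable from compound 1 to compound 3. Neither has a readable size, and neither replaces fluoro with tert-butyl, so they are only a weak guide.

Compound 4 is therefore expected to stay near the limit in this assay, with no clear step in either direction. The expected step is a number no higher from compound 1 to compound 4 (the limit leaves the size open). The estimate for compound 4 is 25000 nM, with an estimated range from 12000 nM to 50000 nM.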

Compound 4, half-maximal effective concentration: > 25000 nM
Compound 4 ended at the assay's limit (the forecaster's own chance of this, stated with the estimate: 80%); the middle value sits exactly at the limit.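

Compound 1 and compound 4 both give a limit of the assay and not a number, so the step between them cannot be read. The compounds shown leave open how much of each is needed for the effect, and whether changing the group matters: the limit of > 25000 nM in this assay, at which 4 of the 4 values shown sit.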